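The compounds below may be only part of what the source reports. "The series", "measured", "known", "first", "only" and "open" are said of these compounds alone.

Measured compounds in an assay on isolated protein for inhibition of DNA topoisomerase 1 (Homo sapiens), with a stated time of 30 min, tested at 100 uM; a lower number here means a weaker effect, a higher number a stronger effect of the compound at the concentration tested:
- compound 1, `Oc1ccc(-c2cc(-c3ccc(Cl)cc3)nc(-c3cccnc3)c2)cc1`: compound 1 gives 18.8%
- compound 2, `Oc1ccc(-c2cc(-c3cccnc3)nc(-c3cccc(Cl)c3)c2)cc1`: compound 2 gives 55.2%
- compound 3, `Oc1ccc(-c2cc(-c3cccnc3)nc(-c3ccccc3Cl)c2)cc1`: compound 3 gives 0.9%

Compound 2 stands highest of the three numbers in this assay; its nearest neighbour is compound 1 (a number 36.4 percentage points higher from compound 1 to compound 2 (beyond the scatter)), and compound 3 is furthest (a number 54.3 percentage points lower from compound 2 to compound 3 (beyond the scatter)), both steps beyond the scatter. The step of a number 17.9 percentage points lower from compound 1 to compound 3 (beyond the scatter) completes the set. All three measured steps concern only the position of the chlorine on the chlorophenyl group; none touches the pyridin-3-yl group.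

Compound 4, `Oc1ccc(-c2cc(-c3ccccc3)nc(-c3cccc(Cl)c3)c2)cc1`, is the next compound. Its change from compound 2 is phenyl in place of pyridin-3-yl on an aromatic carbon. Going by the values given here, no measured step bears on this change, since the pyridin-3-yl group is kept in compounds 1, 2 and 3. The measured steps show only that the series can move by large amounts in this assay from a single ring change, so the direction for compound 4 is open and the uncertainty wide.

Compound 4 is therefore expected to give about 45% in this assay, within a range from 15% to 75%. This expected step is a number 10.2 percentage points lower from compound 2 to compound 4 (beyond the scatter), which may lie within the scatter.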

Compound 4, a percentage reported as inhibition, at one concentration (the size of the read-out at that concentration, not a potency): 0%
Estimate against measurement, compound 4: 45 percentage points above; measured number below the stated range.
By their numbers in this assay, from the lowest: compounds 4 and 3 (each within the scatter of the next); then compound 1; then compound 2.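

In this assay, the pyridin-3-yl group, kept in compounds 1, 2 and 3, now proves decisive for the read-out of compound 2: with phenyl in its place, on the aromatic carbon next to the ring nitrogen, the result is a number 55.2 percentage points lower from compound 2 to compound 4 (beyond the scatter), and no inhibition remains at the concentration tested. The swap leaves the heavy-atom count unchanged and removes only the hetero atom of that ring with its hydrogen-bond acceptor, yet this step belongs to the same large class as the one from moving the chlorine, a number 54.3 percentage points lower from compound 2 to compound 3 (beyond the scatter). No measurement shown here explains the loss.

Going by these compounds, the finding rests on a single pair with the 3-chlorophenyl group, so whether the same swap matters alongside the 4-chlorophenyl or 2-chlorophenyl group remains open. Also open, on these data alone, is whether pyridin-2-yl, pyridin-4-yl, or a phenyl carrying an amine or a carboxylic acid at this place would give a number close to that of compound 2, 55.2%, or one close to that of compound 4, 0%.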